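This account rests on a few compounds, and the source may have more. Where it says the series, first, only, none or still open, it means among the compounds named here.

Measured compounds:
compound 1, `CCOC(=O)c1c(C)nc(-c2ccccc2C#N)n1OC` — 14900 nM
compound 2, `CCOC(=O)c1c(C)nc(-c2cccc(C#N)c2)n1OCCCO` — 11400 nM

Of the compounds shown here, two share the core and have been measured in a functional assay on a cell-free system (plasma, Oryctolagus cuniculus) for inhibition, with stated times of 5 min, 1 min and 6 min; a higher number here means a weaker inhibitor, a lower number a stronger inhibitor. Compound 1 gives 14900 nM in this assay, and compound 2 gives 11400 nM. The two numbers lie within the usual scatter of each other, so compound 2 cannot be set apart from compound 1; both sit at the weak end of what such an assay reports.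

Compound 3, `CCOC(=O)c1c(C)nc(-c2cccc(C#N)c2)n1OCc1ccc([N+](=O)[O-])cc1`, has not yet been measured. It differs from compound 2 in one place:

4-nitrophenyl in place of 2-hydroxyethyl on a saturated chain carbon bound to an oxygen on an aromatic ring

Going by the values given here, no step between measured compounds speaks to this change, since no pair among the measured compounds differs in a single place. The expectation for compound 3 therefore rests only on the structural change and on where compound 2 stands. A modest gain in potency for compound 3 is expected, with the step of a 1.9-fold lower number from compound 2 to compound 3 (0.28 log units; within the scatter) estimated to lie somewhat beyond the scatter but uncertain in direction. Compound 3 is estimated at 6000 nM, within a range from 2000 nM to 20000 nM.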

Compound 3, half-maximal inhibitory concentration: 8750 nM
The estimate for compound 3 lay 1.5-fold (0.16 log units) below the measured number; the measured number falls inside the stated range.
By their numbers in this assay, from the lowest: compounds 3, 2 and 1 (each within the scatter of the next).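

In this assay, putting 4-nitrophenyl in place of 2-hydroxyethyl on a saturated chain carbon bound to an oxygen on an aromatic ring gives a 1.3-fold lower number from compound 2 to compound 3 (0.11 log units; within the scatter), so the numbers for the two compounds cannot be told apart. This position therefore tolerates a group of 9 heavy atoms with a six-membered aromatic ring in place of one of 3 heavy atoms with no ring, and the hydrogen-bond donor of the leaving group is not needed to hold the number at this level. No independent measurement bears on this result, so the comparison stops at the numbers themselves.

The compounds shown leave open whether any group at this position can move the number beyond the scatter: an amine or a carboxylic acid at the end of the chain, a longer chain, or a plain benzyl group without the nitro group would each test this. Compound 1 differs from compound 2 in more than one place, so the place of the nitrile on the shared core remains unseparated from the chain.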